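Tying an open group into a ring

The source may hold more compounds than are shown below. What is called first, only, known or untested is meant among the compounds shown, and "the series" means these compounds.

In a physicochemical assay for solubility, at pH 6.6 (on this read-out lower numbers stand for lower solubility and higher numbers for higher solubility), compound 1 `CC(C)(c1ccccc1)c1nc2c(C(F)(F)F)cccc2c(C(=O)O)c1O` gives 2810 ug/mL and compound 2 `CC(Cc1ccccc1)c1nc2c(C(F)(F)F)cccc2c(C(=O)O)c1O` gives 1550 ug/mL. These two numbers lie within the usual scatter of repeated measurements, so compound 2 stands level with compound 1 on the evidence so far.

Compound 3 `O=C(O)c1c(O)c(C2Cc3ccccc3C2)nc2c(C(F)(F)F)cccc12` keeps the shared core and alters one group: 2,3-dihydro-1H-inden-2-yl in place of 1-benzylethyl on an aromatic carbon. The open 1-benzylethyl gives way to 2,3-dihydro-1H-inden-2-yl, which brings a five-membered non-aromatic ring of carbon only.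

Among the measured compounds shown here, only one measured step bears on this change, since it also exchanged the group on this aromatic carbon: a 1.8-fold lower number from compound 1 to compound 2 (0.26 log units; within the scatter). That single step stayed inside the scatter, and one step is thin evidence. Even so, nothing measured points to a direction, so no shift beyond the scatter is expected in this assay. The expected result is a 1.0-fold lower number from compound 2 to compound 3 (0.01 log units; within the scatter). For compound 3 the estimated solubility is 1500 ug/mL, with an expected range of 650 ug/mL to 3200 ug/mL.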

Compound 3, solubility: 700 ug/mL
Compound 3: middle estimate off by 2.1-fold (0.33 log units), on the high side; low and high end bracket the measured number.
By their numbers in this assay, from the lowest: compound 3; then compounds 2 and 1 (each within the scatter of the next).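

Tying the open 1-benzylethyl into 2,3-dihydro-1H-inden-2-yl adds a five-membered non-aromatic ring without changing the number of heavy atoms, and in this assay this change gives a 2.2-fold lower number from compound 2 to compound 3 (0.35 log units; beyond the scatter) on this aromatic carbon, whereas the earlier exchange at the same place stayed inside the scatter. Measured against the 1-methyl-1-phenylethyl group, the same ring gives a 4.0-fold lower number from compound 1 to compound 3 (0.60 log units; beyond the scatter) so compound 3 now stands lowest of the three, with beyond-scatter steps to both others, while compound 1 and compound 2 remain level with each other. Nothing measured alongside these numbers offers a reason for the shift.

The compounds shown cannot separate the effect of closing a ring from the effect of this particular ring size, and a six-membered ring of carbon only, such as 1,2,3,4-tetrahydronaphthalen-2-yl, would help to tell the two apart. From the compounds shown here alone, it also remains open how this position would respond to a ring holding a nitrogen, such as a piperidine, or to an amine or a carboxylic acid placed on the ring of compound 3.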